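This account rests on a few compounds, and the source may have more. Where it says the series, first, only, none or still open, it means among the compounds named here.

Compound 1 `Cc1cc(C)c(Oc2cc(Nc3ccc(C#N)cc3)ncc2C(=O)NCc2cn(Cc3ccccc3[N+](=O)[O-])nn2)c(C)c1` gives > 212000 nM in an ADME assay on MT4 cells (Homo sapiens) for cytotoxicity, read by MTT assay, with a stated time of 5 days; on this read-out lower numbers stand for higher toxicity in this test and higher numbers for lower toxicity in this test.
Compound 2 `Cc1cc(C)c(Oc2cc(Nc3ccc(C#N)cc3)ncc2C(=O)NCc2cn(Cc3ccccc3C#N)nn2)c(C)c1` gives > 219000 nM in this assay.
Compound 3 `Cc1cc(C)c(Oc2cc(Nc3ccc(C#N)cc3)ncc2C(=O)NCc2cn(Cc3cccc(C#N)c3)nn2)c(C)c1` gives >= 129000 nM in this assay.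

For compound 1 this entry is a limit of the assay and not a number: it sits at the limit of > 212000 nM in this assay, at which 1 of the 3 values shown sits. Compound 2 likewise sits at a limit, (the limit of > 219000 nM in this assay, at which 1 of the 3 values shown sits). Compound 3 too sits at a limit, (the limit of >= 129000 nM in this assay, at which 1 of the 3 values shown sits). None of the three can be placed on a scale, so compound 1 stands only at its limit, alongside two further limits.

Compound 4 `Cc1cc(C)c(Oc2cc(Nc3ccc(C#N)cc3)ncc2C(=O)NCc2cn(Cc3cccc([N+](=O)[O-])c3)nn2)c(C)c1` differs from compound 1 in one place: 3-nitrophenyl in place of 2-nitrophenyl on a saturated chain carbon bound to an aromatic nitrogen. Going by the values given here, three measured steps bear on this change. The move from 2-cyanophenyl to 3-cyanophenyl is seen in a step that the two limits leave unreadable from compound 2 to compound 3, the move from 2-nitrophenyl to 3-cyanophenyl in a step that the two limits leave unreadable from compound 1 to compound 3, and the exchange of cyano for nitro in a step that the two limits leave unreadable from compound 1 to compound 2. All three are unreadable from the limits, so neither size nor direction can be drawn from them. The expected outcome is a number no higher from compound 1 to compound 4 (the limit leaves the size open), which amounts to no change the assay could show. Compound 4 is estimated at 210000 nM, within 100000 nM to 420000 nM, most likely again as a limit.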

Compound 4, half-maximal cytotoxic concentration: >= 156000 nM
Compound 4 gave a limit, no number (the forecaster's own chance of this, stated with the estimate: 85%); the middle value is on the limit's open side.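

Compound 4 gives a limit and not a number, as do compound 1, compound 2 and compound 3, so no step among these four compounds can be read. The compounds shown leave open how toxic each one is in this assay and whether 3-nitrophenyl in place of 2-nitrophenyl changes that at all.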